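Ecdysone agonists: swapping substituents on one aromatic ring

The compounds below may be only part of what the source reports. "The series", "measured", "known", "first", "only" and "open" are said of these compounds alone.

Three compounds share one core. Compound 1 `CC(C)(C)N(NC(=O)c1ccccc1I)C(=O)c1ccccc1Cl` in an assay on cells for agonist activity at ecdysone receptor (Bombyx mori), read by a luciferase reporter, with a stated time of 24 h (on this read-out higher numbers stand for an effect only at larger amounts of compound and lower numbers for an effect already at smaller amounts), gives 1290 nM. Compound 2 `Cc1ccccc1C(=O)NN(C(=O)c1ccccc1Cl)C(C)(C)C` in this assay gives 72.4 nM, and compound 3 `COc1cccc(C(=O)NN(C(=O)c2ccccc2Cl)C(C)(C)C)c1` gives 52.5 nM. Compound 3 sits at the low end of the three: compound 1 lies far above it, as a 25-fold lower number from compound 1 to compound 3 (1.39 log units; beyond the scatter) shows, while a 1.4-fold lower number from compound 2 to compound 3 (0.14 log units; within the scatter) is within the scatter. Compound 4 `Cc1ccc(C(=O)NN(C(=O)c2ccccc2Cl)C(C)(C)C)cc1` differs from compound 3 by 4-methylphenyl in place of 3-methoxyphenyl on a carbonyl carbon. Among the measured compounds shown here, the steps that bear on this are an 18-fold lower number from compound 1 to compound 2 (1.25 log units; beyond the scatter), a large change, and a 1.4-fold lower number from compound 2 to compound 3 (0.14 log units; within the scatter), a negligible one, so two differently substituted aromatic rings already give similar numbers. For compound 4 a change within the scatter is therefore expected, a 1.3-fold higher number from compound 3 to compound 4 (0.12 log units; within the scatter). Compound 4 is estimated at 70 nM, in a range of 20 nM to 250 nM.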

Compound 4, half-maximal effective concentration: 18.6 nM
Compound 4: the middle estimate sits 3.8-fold (0.58 log units) above what was measured; the whole stated range lies above it.
By their numbers in this assay, from the lowest: compound 4; then compounds 3 and 2 (each within the scatter of the next); then compound 1.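

In this assay, this carbonyl carbon does not treat all substituted phenyl groups alike: 4-methylphenyl in place of 3-methoxyphenyl gives a 2.8-fold lower number from compound 3 to compound 4 (0.45 log units; beyond the scatter) and in place of 2-methylphenyl gives a 3.9-fold lower number from compound 2 to compound 4 (0.59 log units; beyond the scatter) so even the two methyl-bearing rings are told apart. Against 2-iodophenyl the same group gives a 69-fold lower number from compound 1 to compound 4 (1.84 log units; beyond the scatter) and this is the widest gap in the set. Nothing shown here explains these differences. Still open, as far as these compounds go, is how 3-methylphenyl would compare, which would separate the methoxy group from the place it occupies. Also open, from the compounds shown here alone, is what a longer chain or an amine on this ring would do.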